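This account rests on a few compounds, and the source may have more. Where it says the series, first, only, none or still open, it means among the compounds named here.

Measured compounds in an assay (Rattus norvegicus) for inhibition of Fatty-acid amide hydrolase 1 (Homo sapiens); a lower number here means a stronger inhibitor, a higher number a weaker inhibitor:
compound 1 `O=C(CCCCCCc1ccccc1)c1ncc(-c2ccccc2F)o1`: 110 nM
compound 2 `Cc1ccnc(-c2cnc(C(=O)CCCCCCc3ccccc3)o2)c1`: 0.6 nM
compound 3 `Cc1cccc(-c2cnc(C(=O)CCCCCCc3ccccc3)o2)n1`: 3.3 nM

Compound 3 stands second of the three in this assay: its nearest neighbour is compound 2, a 5.5-fold higher number from compound 2 to compound 3 (0.74 log units; beyond the scatter), and its furthest is compound 1, a 33-fold lower number from compound 1 to compound 3 (1.52 log units; beyond the scatter). All three share the same core, and the measured steps change only the aromatic group on the five-membered ring, a 180-fold lower number from compound 1 to compound 2 (2.26 log units; beyond the scatter) being the largest of them.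

Compound 4 `O=C(CCCCCCc1ccccc1)c1ncc(Cl)o1` is not yet measured. Relative to compound 3 it differs as follows: chloro in place of 6-methylpyridin-2-yl on an aromatic carbon. Among the compounds with values here, no measured step removes the aromatic group from this position altogether; the three steps so far swap one six-membered aromatic ring for another, and those swaps alone move the number widely, as a 180-fold lower number from compound 1 to compound 2 (2.26 log units; beyond the scatter) shows. Compound 4 keeps only a single heavy atom at that carbon, so the bearing of the measured steps is indirect: they show the position is sensitive, but not what a small non-ring group does there. A step toward a higher number, beyond the scatter, is expected, a 300-fold higher number from compound 3 to compound 4 (2.48 log units; beyond the scatter). The estimate for compound 4 in this assay is 1000 nM, with a range from 150 nM to 6000 nM.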

Compound 4, inhibition constant: 5 nM
Compound 4: the middle estimate sits 200-fold (2.30 log units) above what was measured, outside the stated range (below it).
By their numbers in this assay, from the lowest: compound 2; then compounds 3 and 4 (each within the scatter of the next); then compound 1.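

In this assay, an aromatic ring is not required at the carbon next to the ring oxygen: with chloro, 1 heavy atom, in place of the 7 heavy atoms of 6-methylpyridin-2-yl, the result is a 1.5-fold higher number from compound 3 to compound 4 (0.18 log units; within the scatter) and the two compounds cannot be told apart. The rings do not all relate to chloro in the same way, since replacing 4-methylpyridin-2-yl gives an 8.3-fold higher number from compound 2 to compound 4 (0.92 log units; beyond the scatter) while replacing 2-fluorophenyl gives a 22-fold lower number from compound 1 to compound 4 (1.34 log units; beyond the scatter); chloro therefore falls inside the span set by the aromatic groups, and a ring at this carbon can go with either a lower or a higher number than chloro. Nothing shown accounts for these steps or says why a single chlorine matches one ring and differs from the others.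

The compounds shown leave open whether chlorine itself matters at this carbon, a question that hydrogen, fluoro, bromo, methyl, an amine or a carboxylic acid there would address. They also leave open how much of the gap between the rings follows the ring nitrogen and how much the methyl, which unsubstituted phenyl and pyridin-2-yl would help to separate.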